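Chloro on the aryl of the tert-butyl ester: notes

The compounds below may be only part of what the source reports. "The series", "measured", "known", "first", "only" and "open" are said of these compounds alone.

Measured so far:
compound 1, `CCOC(=O)C1=C(C)N(c2ccccc2)C=CC1c1ccccc1`, in a functional assay, tested at 100 ug/mL (a higher number here means a weaker effect of the compound at the concentration tested, a lower number a stronger effect), gives -21.5%
compound 2, `CCOC(=O)C1=C(C)N(c2ccc(Cl)cc2)C=CC1c1ccccc1`, in this assay gives -19.1%
compound 3, `CC1=C(C(=O)OC(C)(C)C)C(c2ccccc2)C=CN1c1ccccc1`, in this assay gives -30.7%

Compound 3 shows the smallest number of the three; its gap to compound 1 lies within the scatter, its gap to compound 2 beyond it. The change from compound 1 to compound 3 is a number 9.2 percentage points lower from compound 1 to compound 3 (within the scatter), a step within the scatter.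

Compound 4, `CC1=C(C(=O)OC(C)(C)C)C(c2ccccc2)C=CN1c1ccc(Cl)cc1`, is not yet measured. It differs from compound 3 by chloro in place of hydrogen on an aromatic carbon. Within the data shown here, the one measured step that bears on this is the same change on the ethyl ester, a number 2.4 percentage points higher from compound 1 to compound 2 (within the scatter), which stayed within the scatter. Among the measured compounds shown here, no other measured pair carries this change. On that single precedent the expected step in this assay is none beyond the scatter, with the number for compound 4 expected to sit near that of compound 3, a number 2.7 percentage points higher from compound 3 to compound 4 (within the scatter). The estimate for compound 4 in this assay is -28%, with a range from -41% to -15%.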

Compound 4, a percentage reported as activity, at one concentration (the size of the read-out at that concentration, not a potency): -24.5%
Compound 4: middle estimate off by 3.5 percentage points, on the low side; the range from low to high includes it.
By their numbers in this assay, from the lowest: compounds 3, 4, 1 and 2 (each within the scatter of the next, the first and the last beyond it).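

In this assay, phenyl to 4-chlorophenyl now has a second reading, on the tert-butyl ester, where the step is a number 6.2 percentage points higher from compound 3 to compound 4 (within the scatter), so the chloro change stays within the scatter on both esters: the same change on two cores in this assay, a number 2.4 percentage points higher (within the scatter) from compound 1 to compound 2 and a number 6.2 percentage points higher (within the scatter) from compound 3 to compound 4, 3.8 percentage points apart, within the scatter of two such steps. The ester change also gains a second reading, on the 4-chlorophenyl pair, with a number 5.4 percentage points lower from compound 2 to compound 4 (within the scatter), and the two readings agree: the same change on two cores in this assay, a number 9.2 percentage points lower (within the scatter) from compound 1 to compound 3 and a number 5.4 percentage points lower (within the scatter) from compound 2 to compound 4, 3.8 percentage points apart, within the scatter of two such steps. Across these four compounds, each change reads alike whichever form the other place carries, and no compound goes against this.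

Open, as far as these compounds go, is whether another group at this place on the aromatic ring, such as an amine or a carboxylic acid, would give a step beyond the scatter. Also open, from the compounds shown here alone, is how an amide in place of the ester, or a longer chain on the ester oxygen, would read in this assay.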